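The compounds below may be only part of what the source reports. "The series", "measured", "known", "first", "only" and "open" are said of these compounds alone.

In an ADME assay on Vero cells (Chlorocebus sabaeus) for cytotoxicity, with a stated time of 72 h (a lower number here means a stronger inhibitor, a higher number a weaker inhibitor), compound 2 `CCOC(=O)c1cc(-c2cccc(OCc3ccccc3[N+](=O)[O-])c2)on1` gives only a limit, > 128000 nM. Its close relative, compound 1 `CCOC(=O)c1cc(-c2cccc(OCc3cccc(N)c3)c2)on1`, likewise reaches only a limit in this assay, > 128000 nM. The step between them is a step that the two limits leave unreadable from compound 1 to compound 2, so the pair says nothing beyond (the limit of > 128000 nM in this assay, at which 2 of the 2 values shown sit), the ceiling on which both values rest. Compound 2 thus stands at the edge of what this assay can report, with no number of its own.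

The next change, (3,5-difluorophenyl in place of 2-nitrophenyl on a saturated chain carbon bound to an oxygen on an aromatic ring), yields compound 3 `CCOC(=O)c1cc(-c2cccc(OCc3cc(F)cc(F)c3)c2)on1`. Among the compounds with values here, the only measured step that bears on it is a step that the two limits leave unreadable from compound 1 to compound 2, which was not readable in size, both of its ends sitting at a limit. Within the data shown here, no measured step therefore offers a direction, and the expectation is simply that compound 3 again shows no inhibition within the reach of this assay. Compound 3 is expected to give about 160000 nM in this assay, within a range from 60000 nM to 500000 nM. The step expected from compound 2 to compound 3 is a step that the limit leaves unreadable from compound 2 to compound 3, which is estimated not to exceed the scatter.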

Compound 3, half-maximal inhibitory concentration: > 128000 nM
Compound 3: only a limit was reported (the forecaster's own chance of this, stated with the estimate: 85%); the middle value does not contradict the limit.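

Compound 3 gives only a limit, > 128000 nM, in this assay, so its steps from compound 1 and from compound 2 cannot be read, and all three compounds rest on the same ceiling: the limit of > 128000 nM in this assay, at which 3 of the 3 values shown sit. The compounds shown leave open how 3-aminophenyl, 2-nitrophenyl and 3,5-difluorophenyl truly compare, and whether any compound on this shared core would give a measurable value.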